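A few compounds are considered here, and "the series" means these few. Any claim that something is new, unique, unknown or untested is made for them only; others in the source may bear on it.

Compounds measured so far:

Compound 1, `COc1ccc2c(=O)c(/C=C/C(=O)Nc3cccc(C)c3)coc2c1`. In a functional assay on A549 cells (Homo sapiens) for inhibition, read by MTT assay, with a stated time of 48 h (a lower number here means a stronger inhibitor, a higher number a weaker inhibitor), compound 1 gives only a limit of the assay, > 100000 nM.
Compound 2, `COc1ccc2c(=O)c(/C=C/C(=O)Nc3cccc(Cl)c3)coc2c1`. In this assay compound 2 gives 470 nM.
Compound 3, `COc1ccc2c(=O)c(/C=C/C(=O)Nc3cc(C)ccc3C)coc2c1`. In this assay compound 3 gives 15500 nM.

Among the two proper numbers, compound 3 stands highest, that is, as the weaker inhibitor of the pair; its nearest neighbour is compound 2, and the change a 33-fold higher number from compound 2 to compound 3 (1.52 log units; beyond the scatter) marks that distance. The remaining value, that of compound 1, is a limit and cannot be ranked.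

The next compound, compound 4, `COc1ccc(NC(=O)/C=C/c2coc3cc(OC)ccc3c2=O)cc1`, has not yet been measured. It differs from compound 3 in one place: 4-methoxyphenyl in place of 2,5-dimethylphenyl on an amide-type nitrogen. The measured steps that bear on this part of the molecule all concern the group on the amide-type nitrogen. The step of an at least 210-fold lower number from compound 1 to compound 2 (2.32 log units; beyond the scatter) was large, the step of an at least 6.4-fold lower number from compound 1 to compound 3 (0.80 log units; beyond the scatter) was at least modest, and the step of a 33-fold higher number from compound 2 to compound 3 (1.52 log units; beyond the scatter) was large. None of them involves a methoxy group, so the direction for compound 4 is uncertain, but these steps show that this position can move the number strongly either way.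

Compound 4 is therefore expected to land near compound 3, at 10000 nM, with a wide range from 1500 nM to 70000 nM. The expected step is a 1.6-fold lower number from compound 3 to compound 4 (0.19 log units; within the scatter).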

Compound 4, half-maximal inhibitory concentration: 23000 nM
For compound 4 the middle estimate is 2.3-fold (0.36 log units) below the measured one; measured number inside the range.
By their numbers in this assay, from the lowest: compound 2; then compounds 3 and 4 (each within the scatter of the next). At a limit, above all of these: compound 1.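

In this assay, replacing 2,5-dimethylphenyl with 4-methoxyphenyl on the amide-type nitrogen gives no change that can be told from the scatter (a 1.5-fold higher number from compound 3 to compound 4 (0.17 log units; within the scatter)), so two differently substituted rings, one with an oxygen and one with carbon only, can give matching results at this position. Compound 4 also falls well short of compound 2 (a 49-fold higher number from compound 2 to compound 4 (1.69 log units; beyond the scatter)), which leaves compound 2, with its 3-chlorophenyl group, as the strongest inhibitor of the four and shows that a change at this position does not have to be large or small by default: it depends on which two groups are compared. The comparison with compound 1 can be read in one direction only (an at least 4.3-fold lower number from compound 1 to compound 4 (0.63 log units; beyond the scatter)), and the value of compound 1 is a limit: the limit of > 100000 nM in this assay, at which 1 of the 4 values shown sits.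

The compounds shown leave open whether the low number of compound 2 belongs to chlorine itself, since no ring here carries a fluoro group, a bromo group, an amine or a carboxylic acid. As far as these compounds go, all four compounds also share one core, so how changes to that core would combine with these rings remains unknown.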